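This account rests on a few compounds, and the source may have more. Where it says the series, first, only, none or still open, it means among the compounds named here.

In an ADME assay on RD cells (Homo sapiens) for cytotoxicity (a higher number here means that more compound is tolerated, a lower number that less compound is tolerated), compound 3 `O=C1Nc2ccc(F)cc2/C1=N/NC(=S)Nc1ccccc1` gives only a limit, > 25000 nM. Compound 1 `O=C1Nc2ccccc2/C1=N/NC(=S)Nc1ccccc1` also gives a limit, > 25000 nM. Compound 2 `Cc1ccc(NC(=O)N/N=C2\C(=O)Nc3ccccc32)cc1` likewise reaches only a limit, > 25000 nM. Because (the limit of > 25000 nM in this assay, at which 3 of the 3 values shown sit), the step that the two limits leave unreadable from compound 1 to compound 3 cannot be sized. Compound 4 `O=C1Nc2ccc(Cl)cc2/C1=N/NC(=S)Nc1ccccc1` differs from compound 3 by chloro in place of fluoro on an aromatic carbon. No measured step in this assay involves a chloro group, so nothing shown bears directly on this exchange; every value sits at the same limit. Compound 4 is therefore expected to sit where compound 3 sits, with an expected step that the limit leaves unreadable from compound 3 to compound 4 that means no change beyond the scatter. The estimate for compound 4 is 40000 nM, expected to range from 15000 nM to 150000 nM.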

Compound 4, half-maximal cytotoxic concentration: > 25000 nM
Compound 4 was reported as a limit (the forecaster's own chance of this, stated with the estimate: 85%); the middle value lies beyond the limit too.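

In this assay no step can be read among compound 1, compound 3 and compound 4, because all three are reported only as limits: the limit of > 25000 nM in this assay, at which 4 of the 4 values shown sit. The compounds shown leave open at what concentration any of them becomes cytotoxic, and whether fluoro or chloro on the shared core changes that concentration.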